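The source may report more compounds than this note shows. Statements on the series, on what has been measured and on what is new or still open speak of the compounds shown alone.

Compounds measured in an ADME assay on BJ cells (Homo sapiens) for cytotoxicity, read by CellTiter-Glo and resazurin assay, with a stated time of 72 h; on this read-out higher numbers stand for an effect only at larger amounts of compound and lower numbers for an effect already at smaller amounts:
Compound 1 `CC(C)N(Cc1cccc(OCCCCCC(=O)O)c1)C(=O)c1ccccc1`: in this assay compound 1 gives > 26000 nM, which is a limit of the assay and not a number.
Compound 2 `CC(C)COc1cccc(-c2ccc(C(=O)N(Cc3cccc(OCCCCCC(=O)O)c3)C(C)C)cc2)c1`: in this assay compound 2 gives > 26000 nM, again a limit rather than a number.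
Compound 3 `CCOC(=O)CCCCCOc1cccc(CN(C(=O)c2ccccc2)C(C)C)c1`: in this assay compound 3 gives > 26000 nM, also a limit.

Compound 3 therefore stands at the limit, and the other two values shown are limits as well, so that the limit of > 26000 nM in this assay, at which 3 of the 3 values shown sit, is all the evidence there is. Compound 4 `CCOC(=O)CCCCCOc1cccc(CN(C(=O)c2ccc(-c3cccc(-c4nnc(C)o4)c3)cc2)C(C)C)c1` differs from compound 3 by 3-(5-methyl-1,3,4-oxadiazol-2-yl)phenyl in place of hydrogen on an aromatic carbon. For the measured compounds named here, two measured steps bear on this change: a step that the two limits leave unreadable from compound 1 to compound 2, in which a substituted phenyl likewise enters on an aromatic carbon, and a step that the two limits leave unreadable from compound 1 to compound 3, which sets up the ethyl ester that compound 3 and compound 4 share. Neither step can be read in size, because both ends sit at the limit of > 26000 nM in this assay, at which 3 of the 3 values shown sit. The step from compound 3 to compound 4 is accordingly expected to be a step that the limit leaves unreadable from compound 3 to compound 4, most likely ending at the limit once more. Compound 4 is estimated at 30000 nM, within a range from 15000 nM to 80000 nM.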

Compound 4, half-maximal effective concentration: > 26000 nM
Compound 4 ended at the assay's limit (the forecaster's own chance of this, stated with the estimate: 85%); the middle value is on the limit's open side.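

The step between compound 3 and compound 4 cannot be read in size, since both ends are limits of the assay and not numbers: the limit of > 26000 nM in this assay, at which 4 of the 4 values shown sit.

The compounds shown leave open where any of the four would take effect in this assay, and whether the 3-(5-methyl-1,3,4-oxadiazol-2-yl)phenyl group changes that.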